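A few compounds are considered here, and "the series" means these few. Any claim that something is new, unique, unknown or untested is made for them only; others in the source may bear on it.

Compound 1 `CCNC(=O)Nc1nc2cc(-c3cccnc3)cc(-c3ccccn3)c2s1`: 6.25 ug/mL in a physicochemical assay for solubility, read by turbidimetry, in phosphate buffer, with a stated time of 24 h, at pH 7.4; a lower number here means a less soluble compound, a higher number a more soluble compound
Compound 2 `CCNC(=O)Nc1nc2cc(-c3ccc(C(=O)O)nc3)cc(-c3ccccn3)c2s1`: 50 ug/mL
Compound 3 `CCNC(=O)Nc1nc2cc(-c3cnc(N4CCC(CC)(C(=O)O)CC4)nc3)cc(-c3ccccn3)c2s1`: a limit of the assay, > 800 ug/mL

Among the two plain numbers, compound 2 stands highest; compound 1 gives the only other number, 6.25 ug/mL. Compound 3 gave only a limit of the assay, not a number. The unmeasured compound 4 `CCNC(=O)Nc1nc2cc(-c3ccc(N4CCC(C)(C(=O)O)CC4)nc3)cc(-c3ccccn3)c2s1` differs from compound 2 in one place: 4-carboxy-4-methylpiperidin-1-yl in place of carboxy on an aromatic carbon. Among the compounds with values here, one measured step bears on this change: an 8.0-fold higher number from compound 1 to compound 2 (0.90 log units; beyond the scatter), where a carboxy entered. Compound 4 keeps a carboxy and gains the ring, and compound 3, with a related ring-borne carboxy, reached (the limit of > 800 ug/mL in this assay, at which 1 of the 3 values shown sits). An upward step is therefore expected in this assay, a 12-fold higher number from compound 2 to compound 4 (1.08 log units; beyond the scatter). Compound 4 is estimated at 600 ug/mL, between 200 ug/mL and 1600 ug/mL, with a fair chance that only a limit is reported.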

Compound 4, solubility: > 800 ug/mL
Compound 4: only a limit was reported; the forecaster's own chance of this, stated with the estimate: 50%; at least 1.3-fold (0.12 log units) between middle value and limit.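

On the aromatic carbon next to the ring nitrogen, moving the carboxy out onto a piperidine ring gives an at least 16-fold higher number from compound 2 to compound 4 (1.20 log units; beyond the scatter) in this assay. Set against hydrogen in that place, the same group gives an at least 120-fold higher number from compound 1 to compound 4 (2.10 log units; beyond the scatter). Compound 4 gave only a limit, so both steps are minimum sizes: the limit of > 800 ug/mL in this assay, at which 2 of the 4 values shown sit.

As far as these compounds go, how far compound 4 lies beyond that limit remains open. Also open, from the compounds shown here alone, is whether a plain piperidine, or one carrying an amine in place of the carboxy, would give a similar number.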